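A few compounds are considered here, and "the series" means these few. Any claim that something is new, unique, unknown or untested is made for them only; others in the source may bear on it.

Compound 1: `CNC(=O)N1CCCc2ccc(NC(=O)c3ccc(-c4ccn(C(C)=O)n4)cc3)cc21` — 91.4%
Compound 2: `CNC(=O)N1CCCc2ccc(NC(=O)c3ccccc3-c3ccccc3)cc21` — 60.4%

In a functional assay on MV4-11 cells (Homo sapiens) for antiproliferative activity, with a stated time of 6 days, tested at 6.25 uM (on this read-out higher numbers stand for a stronger effect at the one concentration tested and lower numbers for a weaker effect), compound 1 gives 91.4%, the higher of the two measured numbers. Compound 2 gives 60.4%, and the gap between them lies beyond the usual scatter. These two compounds differ in more than one place, so their gap cannot be traced to any single change.

Compound 3 `CNC(=O)N1CCCc2ccc(NC(=O)c3ccc(-c4cnn(C(C)=O)c4)cc3)cc21` has not yet been measured. It differs from compound 1 in one place: 1-acetyl-1H-pyrazol-4-yl in place of 1-acetyl-1H-pyrazol-3-yl on an aromatic carbon. The same atoms are present, joined differently. Going by the values given here, no measured pair shows what such a rearrangement does, so the size of the step is not known from the data.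

Because compound 1 already gives 91.4%, compound 3 is expected to land near it, with a small fall that may stay within the scatter. The step from compound 1 to compound 3 is expected to be a number 9.4 percentage points lower from compound 1 to compound 3 (within the scatter) in this assay. Compound 3 is estimated at 82%, with a range from 55% to 96%.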

Compound 3, a percentage reported as inhibition, at one concentration (the size of the read-out at that concentration, not a potency): 83.8%
Estimate against measurement, compound 3: 1.8 percentage points below; the range from low to high includes it.
By their numbers in this assay, from the lowest: compound 2; then compounds 3 and 1 (each within the scatter of the next).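

In this assay, replacing 1-acetyl-1H-pyrazol-3-yl with 1-acetyl-1H-pyrazol-4-yl on the aromatic carbon para to a large group gives a number 7.6 percentage points lower from compound 1 to compound 3 (within the scatter). Going by these compounds alone, this is the first direct view of this position: with the same atoms joined differently, the read-out stays within the usual scatter, so this pair shows no measurable preference between the two attachment points at the one concentration tested. Nothing available explains why the two attachments read alike.

As far as these compounds go, what the acetyl group itself contributes remains open, and a close partner of compound 1 or compound 3 carrying a methyl group or a primary amide in its place could show this. Also open, from the compounds shown here alone, is whether the two attachment points would separate in a full potency measurement, which a single-concentration read-out cannot show.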